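This account rests on a few compounds, and the source may have more. Where it says the series, first, only, none or still open, it means among the compounds named here.

In a functional assay on B16-F10 cells (Mus musculus) (on this read-out higher numbers stand for an effect only at larger amounts of compound and lower numbers for an effect already at smaller amounts), compound 1 `Nc1ncn(C[C@H]2CO[C@H](CO)O2)c(=O)n1` gives 70000 nM, so it acts only at large amounts. Compound 2 `Cc1nn(C[C@@H]2CO[C@H](CO)O2)c(=O)[nH]c1=O` reads > 100000 nM, and this is a limit of the assay, not a number. the limit of > 100000 nM in this assay, at which 1 of the 2 values shown sits, is all that can be said of where compound 2 stands, since it has no exact value.

Compound 3 `Cc1nn(C[C@H]2CO[C@H](CO)O2)c(=O)[nH]c1=O` is very close to compound 2. The change is the two compounds have the same atoms and bonds and differ only in configuration as drawn: 1 of 2 stereo elements differ; a stereocentre at a saturated ring carbon is drawn R in compound 2 and S in compound 3. Nothing leaves and nothing enters, so the only difference is how one stereocentre at a saturated ring carbon is drawn.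

Within the data shown here, no measured pair of compounds here differs in one place, so the effect of such a switch in this assay has not been seen directly. A change in configuration alone can matter, but there is no measured sign of its direction here. With compound 1 at 70000 nM, a result at large amounts remains the most likely outcome.

The expected move is a number no higher from compound 2 to compound 3 (the limit leaves the size open), which is estimated to stay within the scatter and has no favoured direction. For compound 3, the estimated value is 100000 nM, with an expected range of 45000 nM to 200000 nM.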

Compound 3, half-maximal effective concentration: > 100000 nM
Compound 3 gave a limit, no number; the forecaster's own chance of this, stated with the estimate: 65%; the middle value lies on the limit itself.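

No step can be read from compound 2 to compound 3, because neither compound gives a number, only a limit of the assay: the limit of > 100000 nM in this assay, at which 2 of the 3 values shown sit. The compounds shown leave open whether the way the stereocentre at a saturated ring carbon is drawn makes any difference to the effect in this assay.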